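From methyl to methoxy in compound 4

This account rests on a few compounds, and the source may have more. Where it says the series, first, only, none or still open, it means among the compounds named here.

In an ADME assay for permeability, using PAMPA (on this read-out higher numbers stand for higher permeability and lower numbers for lower permeability), compound 1 `CC(=O)N1CCC(C(=O)N2CCC(N3CCN(C(=O)c4cc(-c5ccccc5)nc(-c5ccc6[nH]ccc6c5)c4)CC3)CC2)CC1` gives 46.5 10^-6 cm/s, compound 2 `CC(=O)N1CCC(C(=O)N2CCC(N3CCN(C(=O)c4cc(-c5cccc(F)c5)nc(-c5ccc6[nH]ccc6c5)c4)CC3)CC2)CC1` gives 19.9 10^-6 cm/s and compound 3 `CC(=O)N1CCC(C(=O)N2CCC(N3CCN(C(=O)c4cc(-c5ccc(C)cc5)nc(-c5ccc6[nH]ccc6c5)c4)CC3)CC2)CC1` gives 39.8 10^-6 cm/s. The number for compound 3 lies within the usual scatter of both the others. Compound 4 `COc1ccc(-c2cc(C(=O)N3CCN(C4CCN(C(=O)C5CCN(C(C)=O)CC5)CC4)CC3)cc(-c3ccc4[nH]ccc4c3)n2)cc1` carries methoxy in place of methyl on an aromatic carbon. For the measured compounds named here, the closest precedent, methyl in place of hydrogen on an aromatic carbon, is a 1.2-fold lower number from compound 1 to compound 3 (0.07 log units; within the scatter). Fluoro in place of hydrogen on an aromatic carbon is a 2.3-fold lower number from compound 1 to compound 2 (0.37 log units; beyond the scatter), a modest step. No step beyond the scatter is therefore expected in this assay, and the estimated step is a 1.1-fold lower number from compound 3 to compound 4 (0.06 log units; within the scatter). For compound 4 the expected value is 35 10^-6 cm/s, with an estimated range of 17 10^-6 cm/s to 65 10^-6 cm/s.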

Compound 4, apparent permeability: 21.5 10^-6 cm/s
Compound 4: middle estimate off by 1.6-fold (0.21 log units), on the high side; low and high end bracket the measured number.
By their numbers in this assay, from the lowest: compounds 2, 4, 3 and 1 (each within the scatter of the next, the first and the last beyond it).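

In this assay, the methoxy group at this position gives a 1.9-fold lower number from compound 3 to compound 4 (0.27 log units; within the scatter), so adding the oxygen to the methyl group moves the number no further than the scatter. Set against the unsubstituted phenyl, however, it gives a 2.2-fold lower number from compound 1 to compound 4 (0.34 log units; beyond the scatter), a modest step that methyl did not produce. Compound 4 also stays level with the 3-fluorophenyl compound, with a 1.1-fold higher number from compound 2 to compound 4 (0.03 log units; within the scatter) as the step between them. No measurement shown here explains these steps. Going by these compounds, it remains open how an amine, a carboxylic acid or a longer ether chain at this position would read.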